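The compounds below may be only part of what the source reports. "The series", "measured", "known", "first", "only" and "open" are said of these compounds alone.

The three measured compounds share a saturated bicyclic amine core and were tested in an assay on HEK293 cells for displacement of a labelled ligand from Neuronal acetylcholine receptor; alpha3/beta4 (Rattus norvegicus), with a stated time of 4 h; a lower number here means a stronger inhibitor, a higher number a weaker inhibitor. Compound 1 `COCCO[C@H]1CC[C@H]2CCN(C)[C@H]2C1` carries a 2-methoxyethyl group on an oxygen on a saturated carbon, and in this assay compound 1 gives 300000 nM. Compound 3 `CN1CC[C@@H]2CC[C@H](O)C[C@@H]21` is the same core with that group removed. In this assay compound 3 gives > 300000 nM, which is a limit of the assay and not a number. The change is hydrogen in place of 2-methoxyethyl on an oxygen on a saturated carbon, and the step of a number no lower from compound 1 to compound 3 (the limit leaves the size open) is therefore known only in its direction, not its size.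

Compound 2 `COCCO[C@H]1CC=C2CCN(C)[C@H]2C1` has a different core; how the two cores differ is not broken down here. In this assay compound 2 gives > 300000 nM, which is a limit of the assay and not a number.

Compound 4 `CN1CCC2=CC[C@H](O)C[C@@H]21` stands to compound 2 as compound 3 stands to compound 1: the change is hydrogen in place of 2-methoxyethyl on an oxygen on a saturated carbon, the same change at the same kind of place. Because the limit of > 300000 nM in this assay, at which 2 of the 3 values shown sit, and because the step of a number no lower from compound 1 to compound 3 (the limit leaves the size open) went no lower, compound 4 is expected to show a step of a number no higher from compound 2 to compound 4 (the limit leaves the size open), which cannot be pinned down. On that basis compound 4 is estimated at 300000 nM, with the expected range running from 150000 nM to 1000000 nM, and most likely the assay will again report only a limit.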

Compound 4, inhibition constant: > 300000 nM
Compound 4: no number, only a limit; the forecaster's own chance of this, stated with the estimate: 85%; the middle value lies on the limit itself.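

In this assay, no size can be read for the change from compound 2 to compound 4, as each of the two gives only a limit of the assay and not a number: the limit of > 300000 nM in this assay, at which 3 of the 4 values shown sit.

The compounds shown leave open how large the effect of putting hydrogen in place of 2-methoxyethyl is on either core, and how much weaker than compound 1 the other three compounds are, if they are weaker at all.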